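A few compounds are considered here, and "the series" means these few. Any claim that something is new, unique, unknown or untested is made for them only; others in the source may bear on it.

Compound 1 `CNC(=O)c1cc(-c2cnc(NCc3c(F)ccc4c3CCO4)c3cn[nH]c(=O)c23)n(C)n1` gives 7000 nM in a physicochemical assay for solubility, read by LC-MS, in phosphate buffer, with a stated time of 24 h, at pH 7.4; a lower number here means a less soluble compound, a higher number a more soluble compound.
Compound 2 `O=C1CCCN1c1cnc(NCc2c(F)ccc3c2CCO3)n2cnnc12` gives 640000 nM in this assay.
Compound 3 `CNC(=O)c1ccc(-c2cnc(NCc3c(F)ccc4c3CCO4)c3cn[nH]c(=O)c23)c(C)n1` gives 19000 nM in this assay.

Among these three, compound 2 stands highest in this assay: its number lies well beyond the scatter above both others, the nearer being compound 3 and the further compound 1. For the measured compounds named here, the one measured step that changes a single place is the one from compound 1 to compound 3, where a 2.7-fold higher number from compound 1 to compound 3 (0.43 log units; beyond the scatter). That step swaps one aromatic group for another on a different core, so it does not speak to the change considered here.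

Compound 4 `Fc1ccc2c(c1CNc1ncc(Oc3ccccc3)c3nncn13)CCO2` has not yet been measured in this assay. It differs from compound 2 in one place: phenoxy in place of 2-oxopyrrolidin-1-yl on an aromatic carbon. A lactam ring leaves and a phenoxy enters at the same aromatic carbon of the shared core. Going by the values given here, no measured pair shows this change or anything close to it, so the size and direction of the step can only be guessed. The estimate for compound 4 is 40000 nM, with a range from 6000 nM to 250000 nM. That estimate means a step of a 16-fold lower number from compound 2 to compound 4 (1.20 log units; beyond the scatter), expected to lie below the value of compound 2, with the wide range reflecting the absence of any guiding step.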

Compound 4, solubility: 8000 nM
Compound 4: middle estimate off by 5.0-fold (0.70 log units), on the high side; the measured number falls inside the stated range.
By their numbers in this assay, from the lowest: compounds 1 and 4 (each within the scatter of the next); then compound 3; then compound 2.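

On the aromatic carbon of the shared core, phenoxy in place of 2-oxopyrrolidin-1-yl gives an 80-fold lower number from compound 2 to compound 4 (1.90 log units; beyond the scatter) in this assay. For the compounds shown here, this is the first measured step at this position, and its size shows that the read-out depends strongly on the group placed here, even though the two groups have the same counts of hydrogen-bond donors and acceptors and neither carries a net charge. The groups do differ in their rings, a five-membered non-aromatic ring with one nitrogen against a six-membered aromatic ring of carbon only, but nothing measured here explains the step.

Going by these compounds, a single pair cannot separate the contribution of the aromatic ring from that of the way it is attached, so it remains open whether a cyclohexyloxy group, with a saturated ring on the same oxygen, or a phenyl ring joined directly to the core would sit nearer compound 2 or compound 4. On these data alone, it is equally open how the number would respond to a carboxylic acid or a morpholine ring on the phenoxy group, or to a smaller lactam or an open-chain amide at this carbon.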